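The compounds below may be only part of what the source reports. "The series", "measured", "known", "first", "only" and "open" are said of these compounds alone.

Compound 1 `Nc1ccn(/C=C/C=O)c(=O)n1`: > 100000 nM
Compound 2 `O=C/C=C/n1ccc(=O)[nH]c1=O`: 30000 nM
Compound 3 `Cc1cn(COCCO)c(=O)n(/C=C/C=O)c1=O`: 20000 nM

All three compounds were tested in a functional assay on HeLa cells (Homo sapiens) for inhibition; on this read-out lower numbers stand for stronger inhibition and higher numbers for weaker inhibition. Compound 1 reads > 100000 nM, and this is a limit of the assay, not a number. That leaves two true numbers to compare. Compound 2 gives 30000 nM and compound 3 gives 20000 nM, and these two values lie within the usual scatter of each other, so the data do not rank them.

The next compound to be tested is compound 4 `O=C/C=C/n1cc(CO)c(=O)[nH]c1=O`, which differs from compound 2 in one place: hydroxymethyl in place of hydrogen on an aromatic carbon. In words, hydroxymethyl stands in place of hydrogen on an aromatic carbon, meta to a 2-formylethenyl group.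

Going by the values given here, no measured pair in this small set shows the effect of a single change like this one, so any forecast rests on very little. The best available guide is the value of compound 2, 30000 nM, and the expectation is no step beyond the scatter in this assay, in either direction. The expected change is a 1.2-fold lower number from compound 2 to compound 4 (0.08 log units; within the scatter), an estimate that carries wide uncertainty. For compound 4 the estimated value is 25000 nM, with an expected range from 7000 nM to 90000 nM.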

Compound 4, half-maximal inhibitory concentration: > 100000 nM
Compound 4: only a limit was reported; the forecaster's own chance of this, stated with the estimate: 15%; at least 4.0-fold (0.60 log units) between middle value and limit.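

In this assay, going by these compounds alone, this is the first single change that can be read on the shared core, and it gives an at least 3.3-fold higher number from compound 2 to compound 4 (0.52 log units; beyond the scatter). The aromatic carbon meta to the 2-formylethenyl group is therefore not a place where any change passes without effect, since hydroxymethyl, a group of only 2 heavy atoms and no ring, is enough to move the result beyond the usual scatter towards weaker inhibition. From the compounds shown here alone, compound 4 gives > 100000 nM, which is a limit of the assay and not a number, so the full size of the step stays unknown because the read-out ends there: the limit of > 100000 nM in this assay, at which 2 of the 4 values shown sit.

The compounds shown leave open whether the loss comes from the oxygen-bearing hydroxymethyl in particular or from almost any added group at this carbon, a question that a fluorine atom, a chlorine atom or an aminomethyl group at the same place could help to settle. They also leave open whether the same change has a similar effect on the core of compound 1 or of compound 3, where other parts of the structure differ.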